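Swapping the benzyl substituent and shortening the chain

A few compounds are considered here, and "the series" means these few. Any claim that something is new, unique, unknown or untested is made for them only; others in the source may bear on it.

Measured so far:
compound 1, `O=S(=O)(NCCCCNCc1ccc(Br)cc1)c1cc(C(F)(F)F)cc(C(F)(F)F)c1`: 2100 nM
compound 2, `O=S(=O)(NCCNCc1cccc2ccccc12)c1cc(C(F)(F)F)cc(C(F)(F)F)c1`: 26000 nM

Both compounds were tested in a functional assay on MIA PaCa-2 cells (Homo sapiens) for inhibition, read by MTT assay, with a stated time of 72 h; a higher number here means a weaker inhibitor of growth, a lower number a stronger inhibitor of growth. Compound 1 gives 2100 nM, the lower of the two numbers. Compound 2 gives 26000 nM, a higher number, and the gap between the two lies beyond the usual scatter, so compound 1 is the stronger growth inhibitor of the pair. Compound 2 differs from compound 1 in more than one place, so the two values alone show no single cause.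

Compound 3, `COc1ccc(CNCCCNS(=O)(=O)c2cc(C(F)(F)F)cc(C(F)(F)F)c2)cc1`, has not been measured. Compared with compound 1 the change is (4-methoxybenzyl)amino in place of ((4-bromobenzyl)amino)methyl on a saturated chain carbon, three bonds along the chain from a sulfonamide nitrogen. Two things move at once: the chain between the sulfonamide nitrogen and the amine becomes shorter by one link, and a methoxy group takes the place of the bromine on the aromatic ring. For the measured compounds named here, no measured pair isolates either change, so the expectation rests on compound 1 alone. A small loss is expected: the step from compound 1 to compound 3 is estimated at a 2.4-fold higher number from compound 1 to compound 3 (0.38 log units; beyond the scatter), toward a higher number. Compound 3 is therefore expected to give about 5000 nM, within a range from 1500 nM to 20000 nM.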

Compound 3, concentration for 50% growth inhibition: 2500 nM
Compound 3: middle estimate off by 2.0-fold (0.30 log units), on the high side; the range from low to high includes it.
By their numbers in this assay, from the lowest: compounds 1 and 3 (each within the scatter of the next); then compound 2.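

In this assay the change to (4-methoxybenzyl)amino in place of ((4-bromobenzyl)amino)methyl, on a saturated chain carbon, three bonds along the chain from a sulfonamide nitrogen, gives a 1.2-fold higher number from compound 1 to compound 3 (0.08 log units; within the scatter). This position therefore accepts the swap: compound 3 carries an oxygen-linked methoxy group and no bromine, yet the assay cannot tell it apart from compound 1. Nothing measured here explains why the two compounds read alike.

The swap alters both the chain and the ring substituent, so the compounds shown leave open whether neither alteration matters or whether the two offset each other. A compound with the bromine on the shorter chain, or the methoxy group on the chain of compound 1, would separate the two, and a longer chain or a chlorine on the benzyl ring would show how far this tolerance extends.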